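This account rests on a few compounds, and the source may have more. Where it says the series, first, only, none or still open, it means among the compounds named here.

Measured compounds in a physicochemical assay for lipophilicity, read by HPLC, measured as chromatographic lipophilicity, at pH 7.4; on this read-out higher numbers stand for higher lipophilicity and lower numbers for lower lipophilicity: compound 1 `CC[C@H]1OC(=O)[C@H](C)[C@@H](O)[C@H](C)[C@@H](O[C@@H]2O[C@H](C)C[C@H](N(C)C)[C@H]2O)[C@](C)(O)C[C@@H](C)CN(C)[C@H](C)[C@@H](O)[C@]1(C)O` gives 1.35; compound 2 `CCCCCCCC(=O)NCCCN(C)[C@H]1C[C@@H](C)O[C@@H](O[C@@H]2[C@@H](C)[C@H](O[C@H]3C[C@@](C)(OC)[C@@H](O)[C@H](C)O3)[C@@H](C)C(=O)O[C@H](CC)[C@@](C)(O)[C@H](O)[C@@H](C)N(C)C[C@H](C)C[C@@]2(C)O)[C@@H]1O` gives 3.74; compound 3 `CC[C@H]1OC(=O)[C@H](C)[C@@H](O[C@H]2C[C@@](C)(OC)[C@@H](O)[C@H](C)O2)[C@H](C)[C@@H](O[C@@H]2O[C@H](C)C[C@H](N(C)CCCNC(C)=O)[C@H]2O)[C@](C)(O)C[C@@H](C)CN(C)[C@H](C)[C@@H](O)[C@]1(C)O` gives 2.06.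

Compound 2 stands highest of the three numbers in this assay. Its nearest neighbour is compound 3, reached by the step from compound 2 to compound 3 of a number 1.68 log units lower from compound 2 to compound 3 (beyond the scatter); its furthest is compound 1, which sits well below it. Compound 4 `CCCCCCCC(=O)NCCCN(C)[C@H]1C[C@@H](C)O[C@@H](O[C@@H]2[C@@H](C)[C@H](O)[C@@H](C)C(=O)O[C@H](CC)[C@@](C)(O)[C@H](O)[C@@H](C)N(C)C[C@H](C)C[C@@]2(C)O)[C@@H]1O` differs from compound 2 in one place: hydrogen in place of 5-hydroxy-4-methoxy-4,6-dimethyloxan-2-yl on an oxygen on a saturated carbon. Among the measured compounds shown here, no measured step covers this change. For the measured compounds named here, the one measured step, from compound 2 to compound 3, sits on the saturated chain carbon bound to the carbonyl carbon and not on the oxygen in question, so it gives no direct guide. Going by the values given here, compounds 1 and 3 differ in two places, so their values show only that compound 3 sits above compound 1. With a group of the size counted leaving and hydrogen entering, a downward step in this assay is expected for compound 4, estimated at a number 0.74 log units lower from compound 2 to compound 4 (beyond the scatter). The value expected for compound 4 is therefore 3, in the range 2.3 to 3.6.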

Compound 4, distribution coefficient: 4.84
Compound 4: the middle estimate sits 1.84 log units below what was measured; the measured number lies above the stated range.
By their numbers in this assay, from the lowest: compound 1; then compound 3; then compound 2; then compound 4.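

In this assay, hydrogen in place of 5-hydroxy-4-methoxy-4,6-dimethyloxan-2-yl on an oxygen on a saturated carbon gives a number 1.10 log units higher from compound 2 to compound 4 (beyond the scatter), so at this position losing a group of 11 heavy atoms raises the number rather than lowering it. On the same hydroxy-bearing core, 2-((heptylcarbonyl)amino)ethyl in place of hydrogen on a saturated chain carbon bound to an amine nitrogen gives a number 3.49 log units higher from compound 1 to compound 4 (beyond the scatter). Nothing measured here accounts for the direction of the step at the oxygen.

From the compounds shown here alone, whether the same change at this oxygen moves the number the same way in compound 3, which carries hydrogen in place of hexyl on the chain, remains open. Also open, going by these compounds, is what a smaller group on that oxygen, such as methyl or acetyl, would give.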